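The source may report more compounds than this note shows. Statements on the series, on what has been measured and on what is new or still open speak of the compounds shown alone.

In a functional assay on Mahlavu cells (Homo sapiens) for inhibition, read by sulforhodamine B assay, with a stated time of 72 h (on this read-out lower numbers stand for stronger inhibition and higher numbers for weaker inhibition), compound 1 `CC(C)Cc1ccc(C(C)c2nnc3n2N=C(c2ccc(Br)cc2)CS3)cc1` gives 8900 nM; this is the second highest of the three numbers measured, and both neighbours lie within the scatter of it. Compound 2 `CC(c1ccc(-c2ccccc2)c(F)c1)c1nnc2n1N=C(c1ccc([N+](=O)[O-])cc1)CS2` gives 9400 nM, and compound 3 `CC(c1ccc(-c2ccccc2)c(F)c1)c1nnc2n1N=C(c1ccc(F)cc1)CS2` gives 7400 nM. Within the data shown here, the only measured single change, fluoro in place of nitro on an aromatic carbon, gave a 1.3-fold lower number from compound 2 to compound 3 (0.10 log units; within the scatter). Compound 4 `COc1ccc(C2=Nn3c(nnc3C(C)c3ccc(CC(C)C)cc3)SC2)cc1` differs from compound 1 by methoxy in place of bromo on an aromatic carbon. Among the measured compounds shown here, no measured step bears directly on a bromo to methoxy exchange; the one step available on the shared core stayed within the scatter, and the three measured values sit close together. The expected step in this assay is therefore a 1.0-fold higher number from compound 1 to compound 4 (0.00 log units; within the scatter), none beyond the scatter. Compound 4 is estimated in this assay at 9000 nM, between 4500 nM and 18000 nM.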

Compound 4, half-maximal inhibitory concentration: 13600 nM
Beside the measured number, compound 4's estimate is 1.5-fold (0.18 log units) below it; low and high end bracket the measured number.
By their numbers in this assay, from the lowest: compounds 3, 1, 2 and 4 (each within the scatter of the next).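

Replacing 4-bromophenyl with 4-methoxyphenyl on the shared core gives, in this assay, a 1.5-fold higher number from compound 1 to compound 4 (0.18 log units; within the scatter). Among these compounds, this is the first direct reading for this exchange at this position, para to a large group, and it shows that adding a hydrogen-bond acceptor here leaves the result within the scatter. Nothing measured explains the result.

Among the compounds shown here, an amine or a carboxylic acid at this position remains open, since no step here goes beyond the scatter. Also open, going by these compounds, is whether methoxy behaves alike with the other side chain of compound 2 and compound 3.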